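Taking one methoxy off compound 2

A few compounds are considered here, and "the series" means these few. Any claim that something is new, unique, unknown or untested is made for them only; others in the source may bear on it.

In a functional assay on the whole organism (strain Kunming) with Mus musculus as the target, with a stated time of 0.5 h (on this read-out higher numbers stand for an effect only at larger amounts of compound and lower numbers for an effect already at smaller amounts), compound 1 `COc1cc(OC)c(OC)cc1/C=C/COC(=O)/C=C/c1ccc(OC)c(OC)c1` gives 173 mg/kg, compound 2 `COc1cc(OC)c(OC)cc1/C=C/COC(=O)/C=C/c1cc(OC)c(OC)c(OC)c1OC` gives 155 mg/kg and compound 3 `COc1cc(OC)c(OC)cc1/C=C/COC(=O)/C=C/c1cc(OC)c(OC)c(OC)c1` gives 204 mg/kg. Compound 2 therefore lies within the scatter of both other compounds, and the three values do not separate.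

Compound 4 `COc1cc(OC)c(OC)cc1/C=C/COC(=O)/C=C/c1ccc(OC)c(OC)c1OC` differs from compound 2 by hydrogen in place of methoxy on an aromatic carbon, ortho to a methoxy group and meta to a large group: hydrogen in place of methoxy on an aromatic carbon.

Within the data shown here, two measured steps bear on this change. The same kind of exchange gives a 1.3-fold higher number from compound 2 to compound 3 (0.12 log units; within the scatter). The opposite exchange, methoxy in place of hydrogen, gives a 1.2-fold higher number from compound 1 to compound 3 (0.07 log units; within the scatter). Both steps stay within the scatter, so no shift beyond the scatter is expected in this assay. The expected result is a 1.1-fold higher number from compound 2 to compound 4 (0.04 log units; within the scatter). The estimate for compound 4 is 170 mg/kg, with an expected range from 105 mg/kg to 270 mg/kg.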

Compound 4, dose for half-maximal effect: 203 mg/kg
Compound 4: middle estimate off by 1.2-fold (0.08 log units), on the low side, and the stated range covers the measured number.
By their numbers in this assay, from the lowest: compounds 2, 1, 4 and 3 (each within the scatter of the next).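

In this assay, the methoxy on this aromatic carbon can be exchanged for hydrogen with a 1.3-fold higher number from compound 2 to compound 4 (0.12 log units; within the scatter), while methoxy in place of hydrogen on another carbon of the same ring gives a 1.2-fold higher number from compound 1 to compound 4 (0.07 log units; within the scatter). With compound 4 in hand, the exchange at this position can now be read on two cores, and the two readings agree: the same change on two cores in this assay, a 1.2-fold higher number (0.07 log units; within the scatter) from compound 1 to compound 3 and a 1.3-fold lower number (0.12 log units; within the scatter) from compound 4 to compound 2, 1.5-fold (0.19 log units) apart, within the scatter of two such steps. The exchange on the other carbon can likewise now be read twice, again without a separation: the same change on two cores in this assay, a 1.3-fold higher number (0.12 log units; within the scatter) from compound 2 to compound 3 and a 1.2-fold lower number (0.07 log units; within the scatter) from compound 4 to compound 1, 1.5-fold (0.19 log units) apart, within the scatter of two such steps.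

From the compounds shown here alone, all four compounds carry only methoxy or hydrogen at these places, so the effect of a hydroxy group, an amine or a longer alkoxy chain there remains open. Also open, going by these compounds, is whether any change to the ester or the other aromatic ring would move the number beyond the scatter.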